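The source may report more compounds than this note shows. Statements on the series, on what has been measured and on what is new or still open speak of the compounds shown alone.

Measured compounds in this study:
compound 1 `COc1cc(-c2ccnc3cc(-c4ccc5ccn(C)c5c4)nn23)cc(OC)c1OC` gives 187 nM
compound 2 `COc1cc(-c2ccnc3cc(-c4ccc(N(C)C)cc4)nn23)cc(OC)c1OC` gives 378 nM
compound 3 `COc1ccc(-c2cc3nccc(-c4cc(OC)c(OC)c(OC)c4)n3n2)cc1` gives 373 nM

In a functional assay on HeLa cells (Homo sapiens) for inhibition, read by CCK-8 assay, with a stated time of 48 h (on this read-out lower numbers stand for stronger inhibition and higher numbers for weaker inhibition), compound 3 stands second highest of the three numbers, with both gaps inside the scatter: a 1.0-fold lower number from compound 2 to compound 3 (0.01 log units; within the scatter), and a 2.0-fold higher number from compound 1 to compound 3 (0.30 log units; within the scatter).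

Compound 4 `COc1cc(-c2ccnc3cc(-c4ccc5c(ccn5C)c4)nn23)cc(OC)c1OC` differs from compound 3 in one place: 1-methyl-1H-indol-5-yl in place of 4-methoxyphenyl on an aromatic carbon. The step that bears on this is the reverse of a 2.0-fold higher number from compound 1 to compound 3 (0.30 log units; within the scatter), where a 1-methyl-1H-indol-6-yl group went with the lower number; a 2.0-fold higher number from compound 1 to compound 2 (0.31 log units; beyond the scatter) points the same way. The entering 1-methyl-1H-indol-5-yl group is not the same as that of compound 1, so only a modest lowering is expected, one that may stay within the scatter. For compound 4 the expected result in this assay is 220 nM, between 100 nM and 480 nM, which is an expected 1.7-fold lower number from compound 3 to compound 4 (0.23 log units; within the scatter).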

Compound 4, half-maximal inhibitory concentration: 19 nM
Compound 4: the middle estimate sits 12-fold (1.06 log units) above what was measured; the whole stated range lies above it.
By their numbers in this assay, from the lowest: compound 4; then compounds 1, 3 and 2 (each within the scatter of the next, the first and the last beyond it).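

In this assay the point of attachment on the indole matters at this aromatic carbon: there is a 9.8-fold lower number from compound 1 to compound 4 (0.99 log units; beyond the scatter) when 1-methyl-1H-indol-5-yl replaces 1-methyl-1H-indol-6-yl. Against the two substituted phenyl groups, the 1-methyl-1H-indol-5-yl group gives a 20-fold lower number from compound 3 to compound 4 (1.29 log units; beyond the scatter) and a 20-fold lower number from compound 2 to compound 4 (1.30 log units; beyond the scatter) and so opens gaps larger than any step among compounds 1, 2 and 3. Nothing available here explains these differences. The compounds shown leave open whether a 1H-indol-5-yl group with no methyl, or a 1-ethyl-1H-indol-5-yl group, would keep so low a number.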